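From 2-Fluoroethoxy to 3-Fluoropropoxy: an Expected Step

The source may report more compounds than this note shows. Statements on the series, on what has been measured and on what is new or still open speak of the compounds shown alone.

Measured compounds:
compound 1, `c1ccc(COc2cccc(-c3cn(C4CN5CCC4CC5)nn3)c2)cc1`: 668 nM
compound 2, `FCCOc1cccc(-c2cn([C@H]3CN4CCC3CC4)nn2)c1`: 7050 nM
compound 3, `Oc1ccc(-c2cn([C@@H]3CN4CCC3CC4)nn2)cc1`: 461 nM

In an assay on HEK293 cells for displacement of a labelled ligand from Neuronal acetylcholine receptor; alpha4/beta2 (Homo sapiens), read by scintillation counting, with a stated time of 120 min (on this read-out lower numbers stand for stronger inhibition and higher numbers for weaker inhibition), compound 2 gives 7050 nM, the highest number of the three. Compound 1 gives 668 nM and compound 3 gives 461 nM; both gaps to compound 2 lie beyond the scatter, so compound 2 is the weakest binder of this set. The unmeasured compound 4, `FCCCOc1cccc(-c2cn([C@H]3CN4CCC3CC4)nn2)c1`, differs from compound 2 in a single place: fluoromethyl in place of fluoro on a saturated chain carbon, two bonds along the chain from an oxygen on an aromatic ring. No measured pair in this set isolates that change, so its size cannot be read from the data shown. With only the shared core and the values of compound 1 and compound 3 as context, the step of a 1.6-fold lower number from compound 2 to compound 4 (0.19 log units; within the scatter) is expected to be modest, leaning toward a somewhat lower number but possibly no further than the scatter. Compound 4 is therefore estimated at 4500 nM in this assay, with a range from 1500 nM to 13000 nM.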

Compound 4, inhibition constant: 9010 nM
Estimate against measurement, compound 4: 2.0-fold (0.30 log units) below; the range from low to high includes it.
By their numbers in this assay, from the lowest: compounds 3 and 1 (each within the scatter of the next); then compounds 2 and 4 (each within the scatter of the next).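

In this assay, going by these compounds alone, going from 2-fluoroethoxy to 3-fluoropropoxy gives a 1.3-fold higher number from compound 2 to compound 4 (0.11 log units; within the scatter), the first step in this set that isolates a single change. At this place, then, swapping fluoro for fluoromethyl on a saturated chain carbon, two bonds along the chain from an oxygen on an aromatic ring, does not separate compound 4 from compound 2. No supporting evidence on this result is available to explain it.

As far as these compounds go, whether the same holds for a longer chain such as fluorobutoxy remains open, as does whether the fluorine itself matters, which a propoxy chain without it or one ending in a hydroxyl or an amine would test. The step also leaves open whether the same change would read alike on the opposite stereoisomer of the shared core.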